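Removing the para fluorine from the biaryl acylguanidine

This account rests on a few compounds, and the source may have more. Where it says the series, first, only, none or still open, it means among the compounds named here.

Compound 1 `CCC(C)c1cc(C)c(C(=O)N=C(N)N)cc1S(C)(=O)=O` and compound 2 `Cc1cc(-c2ccc(F)cc2)c(S(C)(=O)=O)cc1C(=O)N=C(N)N` share one core. In a functional assay for inhibition of sodium/hydrogen exchanger (Oryctolagus cuniculus) (a higher number here means a weaker inhibitor, a lower number a stronger inhibitor), compound 1 gives 8 nM, and compound 2 gives 36 nM. Among the compounds with values here, compound 2 thus stands highest of the two numbers; the only measured step in the set is a 4.5-fold higher number from compound 1 to compound 2 (0.65 log units; beyond the scatter). Compound 3 `Cc1cc(-c2ccccc2)c(S(C)(=O)=O)cc1C(=O)N=C(N)N` is not yet measured and differs from compound 2 by hydrogen in place of fluoro on an aromatic carbon. Within the data shown here, no measured step bears directly on this change: the single known step replaces the whole substituent rather than only the fluoro, so it gives no guide to the size of taking one fluorine away. Without precedent, the expected step is a 1.1-fold lower number from compound 2 to compound 3 (0.05 log units; within the scatter), nothing beyond the scatter. Compound 3 is therefore estimated at 32 nM in this assay, with a range from 12 nM to 85 nM.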

Compound 3, half-maximal inhibitory concentration: 19 nM
Estimate against measurement, compound 3: 1.7-fold (0.23 log units) above; measured number inside the range.
By their numbers in this assay, from the lowest: compound 1; then compounds 3 and 2 (each within the scatter of the next).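

In this assay, the fluoro para to a large group carries no step beyond the scatter (a 1.9-fold lower number from compound 2 to compound 3 (0.28 log units; within the scatter)), so 4-fluorophenyl and phenyl cannot be told apart at this position on these two compounds. The step from sec-butyl to an aromatic group stays beyond the scatter without the fluoro (a 2.4-fold higher number from compound 1 to compound 3 (0.38 log units; beyond the scatter)), so the gap to compound 1 does not depend on that one atom. Nothing measured here gives a reason for either step.

Going by these compounds, with hydrogen and fluoro as the only two cases on the phenyl group, it remains open whether a chlorine or a methoxy group in place of the fluoro would move the number beyond the scatter. Also open, on these data alone, is how a shorter chain such as isopropyl in place of sec-butyl would compare with compound 1.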